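Sulfur for Oxygen on the Carbamoyl of Compound 1

The compounds below may be only part of what the source reports. "The series", "measured", "known", "first", "only" and "open" are said of these compounds alone.

Measured compounds in a functional assay for inhibition, with Homo sapiens as the target; on this read-out lower numbers stand for stronger inhibition and higher numbers for weaker inhibition:
- Compound 1 `CCCCCCCCCCN1CCCC(C(=O)N(CC)CC)C1` gives 242000 nM in this assay.
- Compound 2 `CCN(CC)C(=O)C1CCCN(Cc2ccc(Cl)cc2)C1` gives 217000 nM in this assay.

Compound 1 has the higher of the two numbers, but its gap to compound 2 lies within the usual scatter, so the two values show no order between them. Compound 3 `CCCCCCCCCCN1CCCC(C(=S)N(CC)CC)C1` has not yet been measured in this assay. It differs from compound 1 in one place: a group of 7 heavy atoms (5 carbon, 1 nitrogen, 1 sulfur; no ring) in place of a group of 7 heavy atoms (5 carbon, 1 nitrogen, 1 oxygen; no ring), on a saturated ring carbon. The diethylcarbamoyl leaves and a group of the same heavy-atom count with sulfur in place of oxygen enters, on a saturated ring carbon of the shared core. Going by the values given here, no measured pair shows such a step, so nothing in the data points to a direction. The step from compound 1 to compound 3 in this assay is expected to stay within the scatter, as a 1.1-fold lower number from compound 1 to compound 3 (0.04 log units; within the scatter). Compound 3 is therefore estimated at 220000 nM, between 80000 nM and 600000 nM.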

Compound 3, half-maximal inhibitory concentration: 358000 nM
Compound 3: the middle estimate sits 1.6-fold (0.21 log units) below what was measured, and the stated range covers the measured number.
By their numbers in this assay, from the lowest: compounds 2, 1 and 3 (each within the scatter of the next).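

Going by these compounds alone, the exchange of oxygen for sulfur on the saturated ring carbon of the shared core gives the only single-place step at this position, and in this assay it amounts to a 1.5-fold higher number from compound 1 to compound 3 (0.17 log units; within the scatter). At this position and on this decyl-free comparison of like-sized groups, the read-out therefore shows no change that can be told from the scatter, so this exchange of one atom does not separate the two compounds. Nothing available here bears on the reason for this result.

The compounds shown leave open whether the read-out at this ring carbon responds to a larger change, such as a carboxylic acid, a primary amine or a longer chain on the amide nitrogen in place of the diethylcarbamoyl. They also leave open whether the same exchange of oxygen for sulfur would give a similar step on compound 2.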